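This account rests on a few compounds, and the source may have more. Where it says the series, first, only, none or still open, it means among the compounds named here.

Values in a functional assay on MDA-MB-468 cells (Homo sapiens) for antiproliferative activity, read by sulforhodamine B assay, with a stated time of 4 days (a higher number here means a weaker inhibitor of growth, a lower number a stronger inhibitor of growth), so far

compound 1 `COc1cc(Cl)c(-c2nc(SCC(=O)NC(C)C)nc3[nH]cc(C#N)c23)cc1O` gives 178 nM
compound 2 `CCNC(=O)CSc1nc(-c2cc(OCC)c(OC)cc2Cl)c2c(C#N)c[nH]c2n1` gives 64 nM

Of these two, compound 2 at 64 nM has the lower number, and the gap up to compound 1 lies beyond the usual scatter. Compound 3 `CCOc1cc(-c2nc(SCC(=O)NC(C)C)nc3[nH]cc(C#N)c23)c(Cl)cc1OC` has not yet been measured. It differs from compound 2 by methyl in place of hydrogen on a saturated chain carbon bound to an amide-type nitrogen and a saturated chain carbon in one place, with methyl in place of hydrogen on a saturated chain carbon bound to an amide-type nitrogen and a saturated chain carbon. This turns ethylcarbamoyl into isopropylcarbamoyl.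

Going by the values given here, no measured pair isolates this change. Compound 1 also carries isopropylcarbamoyl, but it differs from compound 2 in more than one place, so its gap cannot be assigned to this change alone. In this assay the expectation is therefore a small step, probably none beyond the scatter, with a slight lean toward a higher number. The lean rests only on compound 1 at 178 nM and is weak. The estimated change is a 1.3-fold higher number from compound 2 to compound 3 (0.12 log units; within the scatter) in this assay. For compound 3 the expected value is 85 nM with an estimated range of 35 nM to 200 nM in this assay.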

Compound 3, concentration for 50% growth inhibition: 77 nM
Compound 3: the middle estimate sits 1.1-fold (0.04 log units) above what was measured; the measured number falls inside the stated range.
By their numbers in this assay, from the lowest: compounds 2 and 3 (each within the scatter of the next); then compound 1.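

In this assay, methyl in place of hydrogen on a saturated chain carbon bound to an amide-type nitrogen and a saturated chain carbon, which turns ethylcarbamoyl into isopropylcarbamoyl, gives a 1.2-fold higher number from compound 2 to compound 3 (0.08 log units; within the scatter), so no difference between these two groups can be read at this position. Going by these compounds alone, with isopropylcarbamoyl held constant, ethyl in place of hydrogen on an oxygen on an aromatic ring gives a 2.3-fold lower number from compound 1 to compound 3 (0.36 log units; beyond the scatter), and of the two single changes now readable, only this one gives a step beyond the scatter. No measurement on these compounds accounts for either step.

From the compounds shown here alone, how far the tolerance at the amide-type nitrogen extends remains open, since a longer chain, a cyclopropyl ring or a chain ending in an amine lies outside the two groups compared here. On the oxygen on the aromatic ring, the compounds shown compare only hydrogen and ethyl, leaving open how a methyl or propyl group there would compare.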